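The source may hold more compounds than are shown below. What is called first, only, known or untested is meant among the compounds shown, and "the series" means these compounds.

Working notes on the imidazopyrazine series.

Compound 1 `O=Cc1ccc(-c2cn3ccnc3c(-c3ccc4ncn(C5CCCCC5)c4c3)n2)cc1` carries a cyclohexyl on the aromatic nitrogen of its fused two-ring system. In a functional assay on SNB-19 cells (Homo sapiens) for inhibition, read by sulforhodamine B assay, with a stated time of 48 h, tested at 10 uM (on this read-out lower numbers stand for less inhibition and higher numbers for more inhibition at the one concentration tested (going by the name of the read-out)), compound 1 gives 14.4%. Compound 2 `O=Cc1ccc(-c2cn3ccnc3c(-c3ccc4ncn(Cc5ccccc5)c4c3)n2)cc1` is its matched partner, differing only by benzyl in place of cyclohexyl on an aromatic nitrogen. In this assay compound 2 gives 14.4%. Across this pair the read-out showed no change at the digits printed from compound 1 to compound 2 (within the scatter), so the exchange of the cyclohexyl for a benzyl left the read-out where it was.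

Compound 3 `c1cn2cc(-c3ccc4c(c3)ncn4C3CCCCC3)nc(-c3ccc4ncn(C5CCCCC5)c4c3)c2n1` belongs to a second core. The difference between the core of compound 1 and the core of compound 3 is not broken down here. In this assay compound 3 gives 10.6%; the gaps to compound 1 and to compound 2 both lie within the scatter, so no order among the three can be drawn.

Compound 4 `c1ccc(Cn2cnc3ccc(-c4nc(-c5ccc6c(c5)ncn6C5CCCCC5)cn5ccnc45)cc32)cc1` has not yet been measured in this assay. It differs from compound 3 by benzyl in place of cyclohexyl on an aromatic nitrogen, the same change as that between compound 1 and compound 2, at a place described in identical words. Among the measured compounds shown here, the step expected here is a number 0.4 percentage points higher from compound 3 to compound 4 (within the scatter), and this expectation rests on no change at the digits printed from compound 1 to compound 2 (within the scatter), the only measured instance of the change. Compound 4 is accordingly expected to give 11% in this assay. The expected range for compound 4 runs from 2% to 22%, reflecting the scatter of single-concentration read-outs of this kind.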

Compound 4, a percentage reported as inhibition, at one concentration (the size of the read-out at that concentration, not a potency): 80.4%
Beside the measured number, compound 4's estimate is 69.4 percentage points below it; measured number above the stated range.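

In this assay, benzyl in place of cyclohexyl on an aromatic nitrogen gives a number 69.8 percentage points higher from compound 3 to compound 4 (beyond the scatter), whereas on the core of compound 1 the same exchange gives no change at the digits printed from compound 1 to compound 2 (within the scatter). The change therefore did not carry over from one core to the other in this series, and the result on one core gave no guide to the result on the other: the same change on two cores in this assay, no change at the digits printed (within the scatter) from compound 1 to compound 2 and a number 69.8 percentage points higher (beyond the scatter) from compound 3 to compound 4, 69.8 percentage points apart, beyond the scatter of two such steps. Among the compounds shown here, this does not show which difference between the two cores goes with the gap, and with only one pair on each core it gives no rule for any further core.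

The compounds shown leave open whether the reading of compound 4 depends on the benzyl itself or would also appear with another group on that aromatic nitrogen, such as a longer alkyl chain, a phenethyl or a chain ending in an amine. They also leave open whether the remaining cyclohexyl of compound 4 contributes to that reading, and, with a single concentration tested, how potent compound 4 is.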